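Swapping methyl for isopropyl in compound 3

The source may report more compounds than this note shows. Statements on the series, on what has been measured and on what is new or still open speak of the compounds shown alone.

In a functional assay on BXPC-3 cells (Homo sapiens) for antiproliferative activity, read by MTT assay, with a stated time of 24 h (a higher number here means a weaker inhibitor, a lower number a stronger inhibitor), compound 1 `CCn1c(C(=O)N[C@H](CO)CCCO)ccc1C(CC)(CC)c1ccc(OCS(=O)(=O)c2ccccc2)c(C)c1` gives > 50000 nM, which is a limit of the assay and not a number. Among the measured compounds shown here, compound 2 `CCn1c(C(=O)N[C@@H](C)C(=O)O)ccc1C(CC)(CC)c1ccc(OCS(=O)(=O)c2ccccc2)c(C)c1` gives 20800 nM, the only actual number so far. For the measured compounds named here, the single measured step is an at least 2.4-fold lower number from compound 1 to compound 2 (0.38 log units; beyond the scatter), and it exchanges a whole group on an amide-type nitrogen. Going by these compounds, that step rests on (the limit of > 50000 nM in this assay, at which 1 of the 2 values shown sits), so its true size stays open.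

Compound 3 `CCn1c(C(=O)N[C@H](C(=O)O)C(C)C)ccc1C(CC)(CC)c1ccc(OCS(=O)(=O)c2ccccc2)c(C)c1` differs from compound 2 by isopropyl in place of methyl on a saturated chain carbon bound to an amide-type nitrogen and a carbonyl carbon. Going by the values given here, no measured step tests this exchange, so the expectation starts from compound 2 at 20800 nM. In this assay, no shift beyond the scatter is expected, and the expected step is a 1.0-fold lower number from compound 2 to compound 3 (0.02 log units; within the scatter). Compound 3 is estimated at 20000 nM, with a range of 8000 nM to 50000 nM.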

Compound 3, half-maximal inhibitory concentration: 16200 nM
Estimate against measurement, compound 3: 1.2-fold (0.09 log units) above; the range from low to high includes it.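

In this assay, isopropyl in place of methyl on the saturated chain carbon bound to an amide-type nitrogen and a carbonyl carbon gives no change that stands out from the scatter (a 1.3-fold lower number from compound 2 to compound 3 (0.11 log units; within the scatter)), so the read-out at this position does not separate the two groups. A second comparison exchanges one group on the amide-type nitrogen for another with the same counts of heavy atoms, carbon and oxygen, and its number still falls beyond the scatter (an at least 3.0-fold lower number from compound 1 to compound 3 (0.48 log units; beyond the scatter)). Going by these compounds, compound 1 stands at a limit of the assay and not at a number, so the full size of that step stays open: (the limit of > 50000 nM in this assay, at which 1 of the 3 values shown sits).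

The compounds shown leave open whether a longer chain or a phenyl group on this carbon would shift the number beyond the scatter. They also leave open what an amine in place of the carboxylic acid would do.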